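Extending the Chain of a Dipropylamino Compound

The source may report more compounds than this note shows. Statements on the series, on what has been measured and on what is new or still open speak of the compounds shown alone.

In a functional assay on LNCaP cells (Homo sapiens) for antiproliferative activity, read by WST assay, with a stated time of 3 days (a lower number here means a stronger inhibitor, a higher number a weaker inhibitor), compound 1 `CCN(CC)CCCOc1c(-c2cc(OC)c(OC)c(OC)c2)oc2ccccc2c1=O` gives 37600 nM, and compound 2 `CCCN(CCC)CCCOc1c(-c2cc(OC)c(OC)c(OC)c2)oc2ccccc2c1=O` gives 17900 nM, the lower of the two numbers. Compound 3 `CCCN(CCC)CCCCCOc1c(-c2cc(OC)c(OC)c(OC)c2)oc2ccccc2c1=O` departs from compound 2 in one place: 2-(dipropylamino)ethyl in place of dipropylamino on a saturated chain carbon, three bonds along the chain from an oxygen on an aromatic ring. For the measured compounds named here, only one measured step offers any guide, the modest 2.1-fold lower number from compound 1 to compound 2 (0.32 log units; beyond the scatter). That step exchanged diethylamino for dipropylamino, so it is a different change and bears on this one only loosely. A similarly modest move to a lower number is expected, a 2.0-fold lower number from compound 2 to compound 3 (0.30 log units; within the scatter). Compound 3 is estimated at 9000 nM, within a range of 3000 nM to 27000 nM.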

Compound 3, half-maximal inhibitory concentration: 7600 nM
Estimate against measurement, compound 3: 1.2-fold (0.07 log units) above; low and high end bracket the measured number.
By their numbers in this assay, from the lowest: compound 3; then compound 2; then compound 1.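

Within this assay, the longer chain at this position gives a 2.4-fold lower number from compound 2 to compound 3 (0.37 log units; beyond the scatter), so 2-(dipropylamino)ethyl in place of dipropylamino lowers the number by a step beyond the scatter. Compared with the diethylamino starting point, the same position gives a 4.9-fold lower number from compound 1 to compound 3 (0.69 log units; beyond the scatter), leaving compound 3 the lowest of the three. Nothing measured here accounts for either step. Going by these compounds, whether a still longer chain, such as 5-(dipropylamino)pentyl, would lower the number further remains open. So does whether a piperidine in place of the dipropylamino group would fare the same on this chain.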